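Swapping 3-(methylsulfanyl)propyl for 2-bromophenyl in compound 3

The source may hold more compounds than are shown below. What is called first, only, known or untested is meant among the compounds shown, and "the series" means these compounds.

In an ADME assay on MT4 cells (Homo sapiens) for cytotoxicity (on this read-out lower numbers stand for higher toxicity in this test and higher numbers for lower toxicity in this test), compound 1 (`CC(=O)NC(=S)Nc1cccc(C(F)(F)F)c1`) gives > 100000 nM, which is a limit of the assay. Among the compounds with values here, compound 2 (`CSCCCNC(=S)Nc1cccc(C(F)(F)F)c1`) gives 43000 nM, the only true number so far. Compound 3 (`FC(F)(F)c1cccc(NC(=S)Nc2ccccc2Br)c1`) carries 2-bromophenyl in place of 3-(methylsulfanyl)propyl on the amide-type nitrogen: 2-bromophenyl in place of 3-(methylsulfanyl)propyl on an amide-type nitrogen. Within the data shown here, the one measured change at this nitrogen, an at least 2.3-fold lower number from compound 1 to compound 2 (0.36 log units; beyond the scatter), is the only guide, and it involved no 2-bromophenyl group. A step of similar size toward a lower number is therefore expected, a 2.9-fold lower number from compound 2 to compound 3 (0.46 log units; beyond the scatter). Compound 3 is estimated at 15000 nM, with an expected range of 4000 nM to 60000 nM.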

Compound 3, half-maximal cytotoxic concentration: 36000 nM
Compound 3: the middle estimate sits 2.4-fold (0.38 log units) below what was measured; the range from low to high includes it.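

In this assay, an aromatic ring and an open chain on this amide-type nitrogen read alike: a 1.2-fold lower number from compound 2 to compound 3 (0.08 log units; within the scatter). Both this 2-bromophenyl compound and the chain compound part from acetyl, with an at least 2.7-fold lower number from compound 1 to compound 3 (0.44 log units; beyond the scatter). Compound 1 stands at a limit of the assay, so the full size of that step cannot be read: the limit of > 100000 nM in this assay, at which 1 of the 3 values shown sits.

The compounds shown leave open whether the bromine plays any part, as a plain phenyl would test. On these data alone, how an amine or a carboxylic acid on this nitrogen would read also stays open.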